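The source may hold more compounds than are shown below. What is called first, only, known or untested is meant among the compounds shown, and "the series" means these compounds.

Of the compounds shown here, two from one series have been measured. Compound 1 `CC(C)c1ccc(-c2nc(SCc3cn(CC(=O)NC(=O)Nc4ccccn4)nn3)nc(Nc3ccc(F)cc3)c2C#N)cc1` gives, in a functional assay on B16-F10 cells (Mus musculus) for inhibition, read by MTT assay, with a stated time of 72 h (on this read-out higher numbers stand for weaker inhibition and lower numbers for stronger inhibition), a value of 7250 nM. Compound 2 `CC(C)c1ccc(-c2nc(SCc3cn(CC(=O)NC(=O)Nc4ccccn4)nn3)nc(Nc3cccc([N+](=O)[O-])c3)c2C#N)cc1` gives in this assay a value of 26400 nM, the higher of the two numbers shown. Among the compounds with values here, the only measured step, a 3.6-fold higher number from compound 1 to compound 2 (0.56 log units; beyond the scatter), shows that exchanging a fluorophenyl for a nitrophenyl at this position raised the number. Compound 3 `CC(C)c1ccc(-c2nc(SCc3cn(CC(=O)NC(=O)Nc4ccccn4)nn3)nc(Nc3ccccc3F)c2C#N)cc1` has not yet been measured. It differs from compound 2 by 2-fluorophenyl in place of 3-nitrophenyl on a nitrogen on an aromatic ring. This change runs in the opposite direction to the measured step, though the fluorine now sits at a different position on the ring, so a drop in the number of broadly similar size, beyond the scatter, is expected. Compound 3 is therefore estimated at 9000 nM, with a likely range from 3500 nM to 25000 nM. The expected step reads a 2.9-fold lower number from compound 2 to compound 3 (0.47 log units; beyond the scatter).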

Compound 3, half-maximal inhibitory concentration: 8380 nM
Estimate against measurement, compound 3: 1.1-fold (0.03 log units) above; the range from low to high includes it.
By their numbers in this assay, from the lowest: compounds 1 and 3 (each within the scatter of the next); then compound 2.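

In this assay, putting 2-fluorophenyl in place of 3-nitrophenyl on this nitrogen gives a 3.2-fold lower number from compound 2 to compound 3 (0.50 log units; beyond the scatter) and so brings the number back into the range of the other fluorophenyl compound. The two fluorophenyl compounds cannot be told apart, with a 1.2-fold higher number from compound 1 to compound 3 (0.06 log units; within the scatter), so among these compounds the place of the fluorine on the ring makes no readable difference. Nothing measured here explains why the 3-nitrophenyl compound stands apart from the two fluorophenyl compounds.

As far as these compounds go, it remains open whether the higher number of compound 2 belongs to the nitro group itself or to its place on the ring, a question that a 3-fluorophenyl or a 4-nitrophenyl group on this nitrogen could address. A plain phenyl or a 3-aminophenyl group would show how far this position responds to other groups.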